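From dimethylamino to methoxy on a growth inhibitor

The compounds below may be only part of what the source reports. "The series", "measured", "known", "first", "only" and "open" are said of these compounds alone.

Measured so far in a functional assay on NCI-H522 cells (Homo sapiens) for inhibition (a lower number here means a stronger inhibitor of growth, a higher number a weaker inhibitor of growth), as follows:
compound 1 `CN(C)c1ccc(NS(=O)(=O)c2c(F)c(F)c(F)c(F)c2F)cc1` gives 58 nM
compound 2 `O=S(=O)(Nc1ccc2c(c1)OCCO2)c1c(F)c(F)c(F)c(F)c1F` gives 26 nM

Compound 1 holds the higher number of the two, and the gap down to compound 2 lies beyond the usual scatter. Compound 3 `COc1ccc(NS(=O)(=O)c2c(F)c(F)c(F)c(F)c2F)cc1` keeps the core of compound 1 and carries methoxy in place of dimethylamino on an aromatic carbon para to a large group. Among the measured compounds shown here, no measured pair shows this exchange, so the data offer no direct guide. In this assay no step beyond the scatter is expected, and no firm direction can be given. The only indirect support is that compound 1 at 58 nM and compound 2 at 26 nM lie within a modest span. The expected change is a 1.2-fold lower number from compound 1 to compound 3 (0.06 log units; within the scatter) on this estimate. Compound 3 is expected at 50 nM with an estimated range from 20 nM to 120 nM in this measurement.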

Compound 3, concentration for 50% growth inhibition: < 10 nM
Compound 3: no number, only a limit (the forecaster's own chance of this, stated with the estimate: 2%); middle value at least 5.0-fold (0.69 log units) from the limit.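

In this assay, the aromatic carbon para to a large group proves sensitive to the group it carries: methoxy in place of dimethylamino gives an at least 5.8-fold lower number from compound 1 to compound 3 (0.76 log units; beyond the scatter). Compound 3 gives < 10 nM, which is a limit of the assay and not a number. The step therefore shows a direction and a minimum size, but its full size stays unknown: the limit of < 10 nM in this assay, at which 1 of the 3 values shown sits.

With only this one exchange at the position, the compounds shown do not tell whether the stronger growth inhibition is particular to methoxy or would also appear with a hydroxyl, an ethoxy or a primary amine in the same place. From the compounds shown here alone, whether a smaller substituent such as a methyl or a chlorine would do as well also remains open.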